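From Methoxy to Methyl: One Small Swap on Compound 1

The compounds below may be only part of what the source reports. "The series", "measured", "known", "first", "only" and "open" are said of these compounds alone.

Of the compounds shown here, three have been measured in an ADME assay on 184B5 cells (Homo sapiens) for cytotoxicity, read by MTT assay, with a stated time of 72 h; on this read-out lower numbers stand for stronger inhibition of growth and higher numbers for weaker inhibition of growth. Compound 1 `COc1ccc(OC(=O)Nc2ccc([Se]C#N)cc2)cc1` gives 19200 nM. Compound 2 `CC(C)COC(=O)Nc1ccc([Se]C#N)cc1` gives 21600 nM, and compound 3 `CCCCOC(=O)Nc1ccc([Se][Se]c2ccc(NC(=O)OCCCC)cc2)cc1` gives 26000 nM. Compound 1 has the lowest of the three numbers, yet its gaps to compound 2 and to compound 3 both fall within the usual scatter of this read-out, so the three cannot be separated on these data.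

Compound 4 `Cc1ccc(OC(=O)Nc2ccc([Se]C#N)cc2)cc1` has not yet been measured. It differs from compound 1 in one place: methyl in place of methoxy on an aromatic carbon. Among the compounds with values here, no pair of measured compounds in this set tracks such a change, so the likely effect must be judged from how tightly the three measured numbers cluster. On that basis the expected step is a 1.0-fold higher number from compound 1 to compound 4 (0.02 log units; within the scatter), in no direction beyond the scatter. Compound 4 is therefore estimated at 20000 nM in this assay, with a range from 9000 nM to 45000 nM.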

Compound 4, concentration for total growth inhibition: 8700 nM
Compound 4: middle estimate off by 2.3-fold (0.36 log units), on the high side; the whole stated range lies above it.
By their numbers in this assay, from the lowest: compound 4; then compounds 1, 2 and 3 (each within the scatter of the next).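

In this assay, within the data shown here, the swap of methoxy for methyl on this aromatic carbon, para to a large group, gives a 2.2-fold lower number from compound 1 to compound 4 (0.34 log units; beyond the scatter) and so produces the only step in the set that is read as beyond the scatter. The result shows that the group at this position can shift the number on this read-out, which the tight cluster of the three earlier compounds could not show, and that the shift here is toward stronger inhibition of growth, though only modest in size. The change takes away one heavy atom and the hydrogen-bond acceptor of the methoxy, but the data shown give no measured basis for tying the step to either difference.

From the compounds shown here alone, whether an ethyl group, a chlorine atom or an amine at this same carbon would go further remains open. This single pair also leaves open whether the same swap would give a similar step on another core.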